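The compounds below may be only part of what the source reports. "The series", "measured", "known", "first", "only" and "open" are said of these compounds alone.

Working notes on a series sharing one core, read in an ADME assay for pharmacokinetics; on this read-out higher numbers stand for a longer-lived compound and lower numbers for a shorter-lived compound. Compound 1 `CC[C@H](c1ccc(O)cc1)[C@@H](CC)c1ccc(OCC2CO2)cc1` gives 4 h, compound 2 `CC[C@H](c1ccc(O)cc1)[C@@H](CC)c1ccc(CCl)cc1` gives 1.3 h and compound 3 `CC[C@H](c1ccc(O)cc1)[C@@H](CC)c1ccc(OCC(=O)CCl)cc1` gives 0.25 h, the lowest of the three numbers. Both steps into that low number lie beyond the scatter: a 16-fold lower number from compound 1 to compound 3 (1.20 log units; beyond the scatter) is large and a 5.2-fold lower number from compound 2 to compound 3 (0.72 log units; beyond the scatter) is modest. The remaining step, a 3.1-fold lower number from compound 1 to compound 2 (0.49 log units; beyond the scatter), is also modest.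

Next comes compound 4 `CC[C@H](c1ccc(O)cc1)[C@@H](CC)c1ccc(OCC(=O)CBr)cc1`, with the change (bromo in place of chloro on a saturated chain carbon bound to a carbonyl carbon), bromo in place of chloro on a saturated chain carbon bound to a carbonyl carbon. Within the data shown here, no measured step exchanges chloro for bromo, and the three steps above each replace a larger group, so they bear on this change only loosely. The anchor is therefore compound 3 at 0.25 h. A small downward move, not beyond the scatter, is expected in this assay. The expected step is a 1.3-fold lower number from compound 3 to compound 4 (0.10 log units; within the scatter). For compound 4 the estimate is 0.2 h, with an expected range of 0.1 h to 0.4 h.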

Compound 4, half-life: < 0.5 h
Compound 4 was reported as a limit; the forecaster's own chance of this, stated with the estimate: 5%; the middle value lies beyond the limit too.
By their numbers in this assay, from the lowest: compound 3; then compound 2; then compound 1.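

In this assay compound 4 is reported only as a limit, < 0.5 h. Bromo in place of chloro on this saturated chain carbon therefore gives a step that cannot be read, so the two halogens cannot be ordered here: the limit of < 0.5 h in this assay, at which 1 of the 4 values shown sits. Even so, the new steps place the (bromomethyl)carbonyl end on the short-lived side of the series, as an at least 2.6-fold lower number from compound 2 to compound 4 (0.41 log units; beyond the scatter) and an at least 8.0-fold lower number from compound 1 to compound 4 (0.90 log units; beyond the scatter) are both beyond the scatter, which shows that a short-lived read-out at this position is not confined to the chloro compound.

Going by these compounds, whether bromo shifts the number at all relative to chloro remains open. Also open, on these data alone, is whether a fluoro, a hydroxyl or an amine on this saturated chain carbon would give a longer-lived number.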